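Taking one chain off compound 3

This account rests on a few compounds, and the source may have more. Where it says the series, first, only, none or still open, it means among the compounds named here.

In a functional assay on M12 cells (Homo sapiens) for antiproliferative activity, read by WST assay, with a stated time of 72 h (on this read-out higher numbers stand for an effect only at larger amounts of compound and lower numbers for an effect already at smaller amounts), compound 3 `CCCCCCCC/C=C\c1c(C)c(/C=C/CCCCCCCC)c(C)[n+]2c1CCC2` gives 2.4 uM. Compound 2 `CCCCCCCC/C=C/c1c(C)c(/C=C/CCCCCCCC)c2[n+](c1C)CCC2` gives 2.2 uM, within the scatter of compound 3. Compound 1 `CCCCCCCCCCc1c(C)cc(C)[n+]2c1CCC2`, which carries one chain on the shared core, gives 0.9 uM, a lower number than compound 3 and beyond the scatter.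

The next compound is compound 4 `CCCCCCCC/C=C\c1c(C)cc(C)[n+]2c1CCC2`. The change from compound 3 is a hydrogen atom in place of a group of 10 heavy atoms (10 carbon; no ring), on an aromatic carbon. The site is ortho to two methyl groups, and the dec-1-en-1-yl group remains.

For the measured compounds named here, the only measured step, a 1.1-fold higher number from compound 2 to compound 3 (0.04 log units; within the scatter), lies within the scatter. It offers little guidance on losing a chain, given (the fact that compounds 2 and 3 differ only in the configuration as drawn). It does suggest that the drawn configuration of the remaining double bond need not weigh much in the estimate.

Going by the values given here, the closest guide is therefore compound 1 at 0.9 uM, the one compound with a single chain. This is one comparison, not an established trend, so a step towards a lower number in this assay is expected, with wide uncertainty. The expected change is a 2.4-fold lower number from compound 3 to compound 4 (0.38 log units; beyond the scatter). For compound 4 the estimated value is 1 uM, with an expected range from 0.4 uM to 2.6 uM.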

Compound 4, concentration for half-maximal effect: 1.3 uM
Compound 4: the middle estimate sits 1.3-fold (0.11 log units) below what was measured, within the range that was stated.
By their numbers in this assay, from the lowest: compounds 1, 4, 2 and 3 (each within the scatter of the next, the first and the last beyond it).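

In this assay, replacing the dec-1-en-1-yl group with hydrogen on the aromatic carbon ortho to two methyl groups gives a 1.8-fold lower number from compound 3 to compound 4 (0.27 log units; within the scatter). For the compounds shown here, this is the first single-place reading at this site, and it shows that the second chain can go without a change beyond the scatter, so one dec-1-en-1-yl group on the shared core is enough for an effect in the same range, and compound 4 at 1.3 uM also stands within the scatter of compound 1 at 0.9 uM. Nothing available on the series accounts for the size of this step.

The compounds shown leave open how this aromatic carbon responds to anything other than hydrogen or a dec-1-en-1-yl group, such as a methyl group, an amine, a carboxylic acid or a hexyl chain. They also leave open what happens when the remaining chain is replaced by hydrogen or by a longer chain such as tetradecyl, which would show whether the effect in this assay tracks that chain.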